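Phenyl for naphthalen-2-yl on two related cores

This account rests on a few compounds, and the source may have more. Where it says the series, first, only, none or still open, it means among the compounds named here.

Compound 1 `O=C(COc1ccc2c(=O)cc(-c3ccccc3)oc2c1)Nc1ccc2ccccc2c1`: > 10000 nM, a limit.
Compound 2 `O=C(COc1ccc2c(=O)c(-c3ccccc3)coc2c1)Nc1ccc2ccccc2c1`: 7680 nM.
Compound 3 `O=C(COc1ccc2c(=O)cc(-c3ccccc3)oc2c1)Nc1ccccc1`: > 10000 nM, a limit.

In a functional assay on MT2 cells (Homo sapiens) for antiproliferative activity, read by MTT assay, with a stated time of 72 h (a higher number here means a weaker inhibitor of growth, a lower number a stronger inhibitor of growth), compound 1 reaches only the limit > 10000 nM. Compound 3, which differs from it by phenyl in place of naphthalen-2-yl on an amide-type nitrogen, likewise reaches only the limit > 10000 nM. The step that the two limits leave unreadable from compound 1 to compound 3 therefore cannot be sized, since (the limit of > 10000 nM in this assay, at which 2 of the 3 values shown sit). Compound 2 has the same atoms as compound 1 joined differently; the difference between the two cores is not broken down here. In this assay, going by the values given here, compound 2 gives 7680 nM, the only number among the three. Compound 4 `O=C(COc1ccc2c(=O)c(-c3ccccc3)coc2c1)Nc1ccccc1` differs from compound 2 by phenyl in place of naphthalen-2-yl on an amide-type nitrogen, the same change as from compound 1 to compound 3. Compound 4 is expected to shift by a 1.6-fold higher number from compound 2 to compound 4 (0.19 log units; within the scatter), an expectation resting on the unreadable step that the two limits leave unreadable from compound 1 to compound 3 and on compound 2 standing at 7680 nM. Compound 4 is estimated at 12000 nM.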

Compound 4, concentration for 50% growth inhibition: > 10000 nM
Compound 4: a limit, no number (the forecaster's own chance of this, stated with the estimate: 55%); the middle value is on the limit's open side.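

Phenyl in place of naphthalen-2-yl on an amide-type nitrogen gives an at least 1.3-fold higher number from compound 2 to compound 4 (0.11 log units; that floor lies within the scatter) in this assay. As far as these compounds go, compound 4 gives > 10000 nM, which is a limit of the assay and not a number, so the full size of this step stays unknown. The same change on the core of compound 1 cannot be read, so the data do not show whether the change carries from one core to the other with the same size: the limit of > 10000 nM in this assay, at which 3 of the 4 values shown sit.

The compounds shown leave open whether an amine or a carboxylic acid on the group at the amide-type nitrogen would give a readable number on either core.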